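This account rests on a few compounds, and the source may have more. Where it says the series, first, only, none or still open, it means among the compounds named here.

Working notes on the series. Going by the values given here, in an ADME assay on L02 cells (Homo sapiens) for cytotoxicity, read by MTT assay, with a stated time of 24 h (a higher number here means a weaker inhibitor, a lower number a stronger inhibitor), compound 1 `O=C1/C(=C/c2ccccc2F)CN(S(=O)(=O)c2ccc(F)cc2)C/C1=C\c1ccccc1F` gives 19100 nM and compound 2 `O=C1/C(=C/c2cccc([N+](=O)[O-])c2)CN(S(=O)(=O)c2ccc(F)cc2)C/C1=C\c1cccc([N+](=O)[O-])c1` gives 15500 nM with the two values inside the usual scatter of each other, so compound 2 stands level with compound 1 on the numbers so far. Compound 3 `CC(=O)Nc1ccc(S(=O)(=O)N2C/C(=C\c3cccc([N+](=O)[O-])c3)C(=O)/C(=C/c3cccc([N+](=O)[O-])c3)C2)cc1` differs from compound 2 by acetamido in place of fluoro on an aromatic carbon in one place: acetamido in place of fluoro on an aromatic carbon, para to a large group. Among the compounds with values here, no two measured compounds differ in one place only, so this change has no direct precedent. With compound 1 at 19100 nM and compound 2 at 15500 nM despite their different substituents, no step beyond the scatter is expected in this assay and any drift is expected to be slightly upward. The estimated change amounts to a 1.2-fold higher number from compound 2 to compound 3 (0.06 log units; within the scatter) and is expected to stay within the scatter. Compound 3 is expected at 18000 nM within an estimated range of 8000 nM to 40000 nM for this measurement.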

Compound 3, half-maximal inhibitory concentration: 15800 nM
Beside the measured number, compound 3's estimate is 1.1-fold (0.06 log units) above it; the range from low to high includes it.
By their numbers in this assay, from the lowest: compounds 2, 3 and 1 (each within the scatter of the next).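

Going by these compounds alone, this is the first comparison that changes one place only: in this assay, acetamido in place of fluoro on an aromatic carbon, para to a large group, gives a 1.0-fold higher number from compound 2 to compound 3 (0.01 log units; within the scatter). At this position, then, going from 4-fluorophenyl to 4-acetamidophenyl adds heavy atoms and brings in a hydrogen-bond donor and acceptor, yet the number stays within the scatter. No measurement at hand bears on why the number holds for this pair.

As far as these compounds go, whether this position stays as flat with an amine, a carboxylic acid or a longer chain in place of acetamido remains open. Also open, from the compounds shown here alone, is whether the same change would read the same way with the aromatic groups of compound 1 in place of those shared by compound 2 and compound 3.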